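A few compounds are considered here, and "the series" means these few. Any claim that something is new, unique, unknown or untested is made for them only; others in the source may bear on it.

For the measured compounds named here, compound 2 `O=C(CN1CCN(C(=O)c2cccc(F)c2)CC1)N1CCN(CCCc2c[nH]c3ccc(F)cc23)CC1` gives 169000 nM in an ADME assay on SH-SY5Y cells (Homo sapiens) for cytotoxicity, read by MTT assay, with a stated time of 72 h (on this read-out higher numbers stand for weaker inhibition and lower numbers for stronger inhibition), the highest of the three numbers so far. Compound 1 `Cc1ccc(C(=O)N2CCN(CC(=O)N3CCN(CCCc4c[nH]c5ccc(F)cc45)CC3)CC2)cc1` gives 119000 nM, within the scatter of compound 2, while compound 3 `O=C(CN1CCN(C(=O)c2ccccc2Br)CC1)N1CCN(CCCc2c[nH]c3ccc(F)cc23)CC1` gives 79100 nM, and the step of a 2.1-fold lower number from compound 2 to compound 3 (0.33 log units; beyond the scatter) is the only one here beyond the scatter.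

Compound 4 `COc1ccc2[nH]cc(CCCN3CCN(C(=O)CN4CCN(C(=O)c5cccc(F)c5)CC4)CC3)c2c1` differs from compound 2 in methoxy in place of fluoro on an aromatic carbon. Going by the values given here, no measured step touches the 5-fluoro-1H-indol-3-yl group: a 1.4-fold higher number from compound 1 to compound 2 (0.15 log units; within the scatter) and a 1.5-fold lower number from compound 1 to compound 3 (0.18 log units; within the scatter) both exchange the aryl on a carbonyl carbon, and a 2.1-fold lower number from compound 2 to compound 3 (0.33 log units; beyond the scatter) is modest. Across these three compounds the read-out barely moves, so no step beyond the scatter is expected in this assay for this change either.

Compound 4 is therefore estimated at 160000 nM, range 70000 nM to 360000 nM, an expected step of a 1.1-fold lower number from compound 2 to compound 4 (0.02 log units; within the scatter).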

Compound 4, half-maximal inhibitory concentration: > 200000 nM
Compound 4: only a limit was reported (the forecaster's own chance of this, stated with the estimate: 15%); at least 1.2-fold (0.09 log units) between middle value and limit.
By their numbers in this assay, from the lowest: compounds 3, 1 and 2 (each within the scatter of the next, the first and the last beyond it). At a limit, above all of these: compound 4.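

In this assay compound 4 gives > 200000 nM, which is a limit of the assay and not a number. For the compounds shown here, this is the first change at this position, where 5-methoxy-1H-indol-3-yl replaces 5-fluoro-1H-indol-3-yl, and it gives an at least 1.1-fold higher number from compound 2 to compound 4 (0.07 log units; that floor lies within the scatter), so the change shows no drop in the number, though the true size of the step remains unknown. The reading at this position stops at: the limit of > 200000 nM in this assay, at which 1 of the 4 values shown sits.

Going by these compounds, how far the methoxy compound lies from the fluoro compound remains open. Also open, on these data alone, is how an amine or a carboxylic acid on this aromatic carbon would read.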